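This account rests on a few compounds, and the source may have more. Where it says the series, first, only, none or still open, it means among the compounds named here.

Within the data shown here, compound 1, whose structure is `CNc1nnc(Cn2c(=O)oc3ccc(C)cc32)s1`, is one of two compounds measured in a functional assay on the whole organism for inhibition, with Mus musculus as the target, read by paw edema, with a stated time of 180 min, at a dose of 200 mg/kg by the oral route; a lower number here means a weaker effect, a higher number a stronger effect of the compound at the dose given. In this assay compound 1 gives 46.9%. The other measured compound, compound 2, has the structure `CCn1c(Cn2c(=O)oc3ccc(C)cc32)n[nH]c1=S` and shares the same core; in this assay compound 2 gives 31.8%. Of the two numbers, compound 1 stands higher, and the gap between them is beyond the usual scatter of repeated measurements, so compound 1 is the stronger of the pair on the numbers shown.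

The compound that is not yet measured, compound 3, has the structure `CCNc1nnc(Cn2c(=O)oc3ccc(C)cc32)s1`. It differs from compound 1 in one place: methyl in place of hydrogen on a saturated chain carbon bound to a nitrogen on an aromatic ring. Among the measured compounds shown here, no step between two measured compounds of this kind is available, so the expectation rests on the small size of the change alone. The step from compound 1 to compound 3 is expected to be a number 1.9 percentage points lower from compound 1 to compound 3 (within the scatter), that is, no change beyond the scatter in either direction. Compound 3 is therefore estimated to give 45% in this assay, within a range from 30% to 60%.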

Compound 3, a percentage reported as inhibition, in the whole organism at one dose (the size of the read-out at that dose, not a potency): 71.3%
Compound 3: middle estimate off by 26.3 percentage points, on the low side; measured number above the stated range.
By their numbers in this assay, from the lowest: compound 2; then compound 1; then compound 3.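

In this assay, putting methyl in place of hydrogen on a saturated chain carbon bound to a nitrogen on an aromatic ring, which turns methylamino into ethylamino, gives a number 24.4 percentage points higher from compound 1 to compound 3 (beyond the scatter) and so adds only one carbon to the structure. This shows that the chain at this position is not a silent part of the structure: a change of a single heavy atom can alter the reading at this dose by more than repeated measurements normally would. The earlier pair could not show this, as compound 1 and compound 2 differ in more than one place, and nothing available here explains how the added carbon produces the higher number.

On these data alone, with a single step, it remains open whether the reading would keep rising, level off or fall with a longer chain such as propyl or butyl, or with a branched group such as isopropyl. As far as these compounds go, it is also open how a ring such as cyclopropyl, or a chain ending in a hydroxyl group, would behave at this position, and whether the higher reading would hold at other doses.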